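Pyrimidin-2-yl to 4-Nitrophenyl: Weak Inhibition Carried Forward

The compounds below may be only part of what the source reports. "The series", "measured", "known", "first", "only" and "open" are said of these compounds alone.

Compound 2 `O=C(CN1CCN(c2ncccn2)CC1)Nc1nc2ccccc2[nH]1` holds the top of the two numbers in an assay on isolated protein for inhibition of Rho-associated protein kinase 2 (Homo sapiens), read by immunoassay, with a stated time of 30 min, tested at 1 mM (a lower number here means less inhibition, a higher number more inhibition at the concentration tested (going by the name of the read-out)), giving 15.3%. Among the compounds with values here, its only neighbour, compound 1 `O=C(CN1CCN(c2ccccn2)CC1)Nc1nc2ccccc2[nH]1`, gives 7.83% in this assay, and the step of a number 7.5 percentage points higher from compound 1 to compound 2 (within the scatter) lies within the scatter. Compound 3 `O=C(CN1CCN(c2ccc([N+](=O)[O-])cc2)CC1)Nc1nc2ccccc2[nH]1` carries 4-nitrophenyl in place of pyrimidin-2-yl on an amine nitrogen in a ring. Within the data shown here, no measured step tests this exchange directly; the single step on the same ring nitrogen, a number 7.5 percentage points higher from compound 1 to compound 2 (within the scatter), was small, so compound 3 is expected to move by a number 3.3 percentage points lower from compound 2 to compound 3 (within the scatter), a change not beyond the scatter. Compound 3 is therefore estimated at 12%, within 0% to 30%.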

Compound 3, a percentage reported as inhibition, at one concentration (the size of the read-out at that concentration, not a potency): 77.9%
Compound 3: the middle estimate sits 65.9 percentage points below what was measured, and the stated range ends below it.
By their numbers in this assay, from the lowest: compounds 1 and 2 (each within the scatter of the next); then compound 3.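

With 4-nitrophenyl on the amine nitrogen in a ring, this assay records a number 62.6 percentage points higher from compound 2 to compound 3 (beyond the scatter) and a number 70.1 percentage points higher from compound 1 to compound 3 (beyond the scatter) in a second large step. This position, which showed no step beyond the scatter between pyridin-2-yl and pyrimidin-2-yl, therefore responds strongly to the group it carries. No evidence is available to explain the rise.

The compounds shown leave open whether the nitro group or the ring of carbon only accounts for the step. A plain phenyl, or a phenyl bearing an amine or a carboxylic acid in place of the nitro group, would separate the two.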